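A few compounds are considered here, and "the series" means these few. Any claim that something is new, unique, unknown or untested is made for them only; others in the source may bear on it.

Three close relatives built on one shared core have been measured in an assay on HEK293 cells for inhibition of transient receptor potential cation channel subfamily M member 8 (Homo sapiens), read by FLIPR and calcium flux; a higher number here means a weaker inhibitor, a lower number a stronger inhibitor. Compound 1 `CN(C(=O)c1ccccc1OCc1ccccc1)[C@@H]1CCC[C@H](N)C1` gives 3670 nM. In this assay compound 2 `CCCN(C(=O)c1ccccc1OCc1ccccc1)[C@@H]1CCC[C@H](N)C1` gives 1430 nM. Compound 3 `CC(C)N(C(=O)c1ccccc1OCc1ccccc1)[C@@H]1CCC[C@H](N)C1` gives 5130 nM in this assay, the highest of the three numbers; its gap to compound 1 lies within the usual scatter of such measurements, while its gap to compound 2 lies beyond it. Compound 4 `CCCCN(C(=O)c1ccccc1OCc1ccccc1)[C@@H]1CCC[C@H](N)C1` has not yet been measured. It differs from compound 3 in one place: butyl in place of isopropyl on an amide-type nitrogen. Among the measured compounds shown here, two measured steps bear on this change. The step of a 3.6-fold higher number from compound 2 to compound 3 (0.55 log units; beyond the scatter) shows what happened when a straight chain on that nitrogen was exchanged for a branched one; compound 4 undoes that kind of exchange and then adds one more carbon to the straight chain. The step of a 2.6-fold lower number from compound 1 to compound 2 (0.41 log units; beyond the scatter) shows that lengthening the straight chain went with a lower number. Taken together, a lower number for compound 4 is expected, near compound 2 or somewhat beyond it, with the expected step being a 4.3-fold lower number from compound 3 to compound 4 (0.63 log units; beyond the scatter). The estimate for compound 4 in this assay is therefore 1200 nM, with a range from 400 nM to 3500 nM.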

Compound 4, antagonist equilibrium constant: 1560 nM
For compound 4 the middle estimate is 1.3-fold (0.11 log units) below the measured one; measured number inside the range.
By their numbers in this assay, from the lowest: compounds 2 and 4 (each within the scatter of the next); then compounds 1 and 3 (each within the scatter of the next).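

In this assay the butyl chain on the amide-type nitrogen gives a 3.3-fold lower number from compound 3 to compound 4 (0.52 log units; beyond the scatter), so a straight chain one carbon longer than the isopropyl group sits clearly apart from that branched group, and this comparison now rests on a second straight chain as well as on compound 2. What is new is that lengthening does not keep paying: a 1.1-fold higher number from compound 2 to compound 4 (0.04 log units; within the scatter), so going from propyl to butyl brings no readable change, even though butyl still differs from methyl by a 2.4-fold lower number from compound 1 to compound 4 (0.37 log units; beyond the scatter), and among the straight chains shown the gain appears by propyl and goes no further. Isopropyl stands apart from this picture, with a number within the scatter of compound 1 and not with compounds 2 and 4, and nothing available here explains why the straight and branched groups differ.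

The compounds shown leave open whether a longer chain such as hexyl would hold the number at this level or move it, and whether branching further out along the chain, as in isobutyl, would behave like isopropyl. They also leave open how a chain ending in an amine or a hydroxyl group would read at this nitrogen.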